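This account rests on a few compounds, and the source may have more. Where it says the series, first, only, none or still open, it means among the compounds named here.

Of the compounds shown here, two that share one core have been measured in a functional assay on MCF7 cells (Homo sapiens) for antiproliferative activity, read by MTT assay, with a stated time of 72 h; a lower number here means a stronger inhibitor, a higher number a weaker inhibitor. Compound 1 `CCNC(=O)c1cc(Oc2ccc(NC(=O)c3nn(-c4ccccc4C)c(=O)cc3C)cc2)ccn1` gives 44300 nM in this assay, the higher of the two numbers. Compound 2 `CCCNC(=O)c1cc(Oc2ccc(NC(=O)c3nn(-c4ccccc4C)c(=O)cc3C)cc2F)ccn1` gives 39600 nM in this assay, a number that lies within the usual scatter of that for compound 1, so the two cannot be told apart; both are weak inhibitors. Compound 3 `CCNC(=O)c1cc(Oc2ccc(NC(=O)c3nn(-c4ccc(C)cc4)c(=O)cc3C)cc2)ccn1` has not yet been measured. It differs from compound 1 in one place: 4-methylphenyl in place of 2-methylphenyl on an aromatic nitrogen. For the measured compounds named here, no measured pair shows what this exchange does, so the expectation rests on the change alone and on how close the two measured numbers already are. The step is expected to be about a 1.1-fold lower number from compound 1 to compound 3 (0.04 log units; within the scatter), which is no more than the scatter. The estimate for compound 3 in this assay is 40000 nM, with a range from 15000 nM to 110000 nM.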

Compound 3, half-maximal inhibitory concentration: 51300 nM
Compound 3: middle estimate off by 1.3-fold (0.11 log units), on the low side, and the stated range covers the measured number.
By their numbers in this assay, from the lowest: compounds 2, 1 and 3 (each within the scatter of the next).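

In this assay, 4-methylphenyl in place of 2-methylphenyl on the aromatic nitrogen gives a 1.2-fold higher number from compound 1 to compound 3 (0.06 log units; within the scatter). For the compounds shown here, this is the first direct reading at this position, and it shows that these two placements of the methyl group cannot be told apart in this assay, with both compounds remaining weak inhibitors. Nothing available explains this result.

As far as these compounds go, whether any group on this nitrogen can shift the number beyond the scatter stays open; a plain phenyl, or a phenyl carrying an amine or a carboxylic acid, would test this. From the compounds shown here alone, compound 2 differs from compound 1 in more than one place, so the step between them cannot be read, and the effect of each of its changes remains unknown.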